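The source may hold more compounds than are shown below. What is called first, only, known or untested is meant among the compounds shown, and "the series" means these compounds.

Of the compounds shown here, three share an amide-linked core and have been tested in a functional assay on the whole organism (strain BALB/c) with Mus musculus as the target, with a stated time of 8 h, at a dose of 10 mg/kg; on this read-out higher numbers stand for more inhibition at the one dose given (going by the name of the read-out) and lower numbers for less inhibition. Compound 1 `Cc1ccc(NC(=O)CN2C(=O)NC3(C2=O)c2ccccc2-c2ccccc23)cc1` gives 53.4%, compound 2 `O=C(CN1C(=O)NC2(C1=O)c1ccccc1-c1ccccc12)Nc1ccc(Cl)cc1Cl` gives 84.3%, and compound 3 `O=C(CN1C(=O)NC2(CCCCC2)C1=O)Nc1ccc(Br)cc1` gives 85.1%. Compound 3 stands highest of the three numbers, though its value and that of compound 2 lie within the usual scatter of each other; only compound 1 lies clearly below it.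

Compound 4 `COc1ccc(NC(=O)CN2C(=O)NC3(CCCCC3)C2=O)cc1` has not yet been measured. It differs from compound 3 in one place: methoxy in place of bromo on an aromatic carbon. Within the data shown here, the only measured step that touches the same part of the molecule is a number 30.9 percentage points higher from compound 1 to compound 2 (beyond the scatter), which shows that changing the group on this phenyl ring can shift the read-out by a large amount. The group entering compound 4 is closer in character to the 4-methylphenyl of compound 1 than to the halogenated rings of compounds 2 and 3, so a drop is expected, on the order of a number 30.1 percentage points lower from compound 3 to compound 4 (beyond the scatter), with wide uncertainty. For compound 4 the expected value in this assay is 55%, estimated to lie between 30% and 80%.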

Compound 4, a percentage reported as inhibition, in the whole organism at one dose (the size of the read-out at that dose, not a potency): 56.1%
Beside the measured number, compound 4's estimate is 1.1 percentage points below it; the measured number falls inside the stated range.
By their numbers in this assay, from the lowest: compounds 1 and 4 (each within the scatter of the next); then compounds 2 and 3 (each within the scatter of the next).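

In this assay, exchanging one group on the aromatic carbon, 4-bromophenyl to 4-methoxyphenyl, while the rest of the molecule stays the same gives a number 29 percentage points lower from compound 3 to compound 4 (beyond the scatter) and shows that this single place can move the read-out by itself. The earlier step of a number 30.9 percentage points higher from compound 1 to compound 2 (beyond the scatter) could not show this as cleanly: it sits on a different core and puts 2,4-dichlorophenyl in place of 4-methylphenyl, which alters the ring in more than one place. Nothing measured here offers an explanation for the drop with methoxy.

The compounds shown leave open how an amine, a carboxylic acid or a longer chain at this place would read. They also leave open whether the same exchange of bromo for methoxy would act in the same way on the core of compound 1.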